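A few compounds are considered here, and "the series" means these few. Any claim that something is new, unique, unknown or untested is made for them only; others in the source may bear on it.

Measured so far, in an assay on isolated protein for inhibition of Dihydrofolate reductase (Mus musculus); a lower number here means a less potent compound, a higher number a more potent compound, by a factor of ten per unit of this negative logarithm:
Compound 1 `Cc1cc(S(=O)(=O)F)ccc1COc1ccc(N2C(N)=NC(N)=NC2(C)C)cc1Cl` gives 7.38.
Compound 2 `CC1(C)N=C(N)N=C(N)N1c1ccc(OCc2ccc(S(=O)(=O)F)cc2)c(Cl)c1` gives 7.58.

Compound 2 holds the higher of the two numbers, but the gap to compound 1, a number 0.20 log units higher from compound 1 to compound 2 (within the scatter), is within the scatter, so the two cannot be ordered. The unmeasured compound 3 `CC1(C)N=C(N)N=C(N)N1c1ccc(OCc2ccc(S(=O)(=O)F)c(Cl)c2)c(Cl)c1` differs from compound 2 by chloro in place of hydrogen on an aromatic carbon, at a carbon ortho to a fluorosulfonyl group. Going by the values given here, no measured pair shows a chloro entering anywhere, so the one known step, hydrogen in place of methyl on an aromatic carbon, does not bear on this change; it was within the scatter and only shows that a small change at a ring carbon left this assay unmoved. With nothing pointing in either direction, compound 3 is expected to land close to compound 2, with a number 0.02 log units higher from compound 2 to compound 3 (within the scatter) as the estimated step. For compound 3 the estimate in this assay is 7.6, between 7 and 8.2.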

Compound 3, logarithm of the reciprocal of the active concentration, log(1/C): 7.43
The estimate for compound 3 lay 0.17 log units above the measured number, and the stated range covers the measured number.
By their numbers in this assay, from the lowest: compounds 1, 3 and 2 (each within the scatter of the next).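

In this assay, going by these compounds alone, chloro in place of hydrogen on an aromatic carbon ortho to a fluorosulfonyl group gives a number 0.15 log units lower from compound 2 to compound 3 (within the scatter), so this carbon accepts a single chlorine atom with no step that can be told apart from repeat measurements. Within the data shown here, the earlier pair dealt only with methyl and hydrogen, so this is the first view of a halogen entering on this ring, and of a change at this particular carbon. Nothing measured here offers a cause for the size of this step.

From the compounds shown here alone, whether an amine, a methoxy group or a carboxylic acid on this same carbon would give a step beyond the scatter remains open. Also open, going by these compounds, is whether a longer chain here would be accepted as readily as chloro.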